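Amide substituent series: from ester to diol on the core

A few compounds are considered here, and "the series" means these few. Any claim that something is new, unique, unknown or untested is made for them only; others in the source may bear on it.

Compound 1, `CCn1c(C(=O)N[C@@H](C)C(=O)OC)ccc1C(CC)(CC)c1ccc(OCS(=O)(=O)c2ccccc2)c(C)c1`, in a functional assay on PC-3 cells (Homo sapiens) for antiproliferative activity, read by MTT assay, with a stated time of 24 h (on this read-out lower numbers stand for stronger inhibition and higher numbers for weaker inhibition), gives > 50000 nM, a limit of the assay and not a number.
Compound 2, `CCn1c(C(=O)NCCC(=O)OC)ccc1C(CC)(CC)c1ccc(OCS(=O)(=O)c2ccccc2)c(C)c1`, gives 40400 nM in this assay.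
Compound 3, `CCn1c(C(=O)N[C@H](C)CO)ccc1C(CC)(CC)c1ccc(OCS(=O)(=O)c2ccccc2)c(C)c1`, gives 7790 nM in this assay.

Compound 1 stands only as a limit in this assay, so no number for it is known (the limit of > 50000 nM in this assay, at which 1 of the 3 values shown sits). The step to compound 4, `CCn1c(C(=O)N[C@@H](CO)CCO)ccc1C(CC)(CC)c1ccc(OCS(=O)(=O)c2ccccc2)c(C)c1`, is 3-hydroxy-1-(hydroxymethyl)propyl in place of 1-(methoxycarbonyl)ethyl on an amide-type nitrogen. The measured steps that bear on it are an at least 6.4-fold lower number from compound 1 to compound 3 (0.80 log units; beyond the scatter) and a 5.2-fold lower number from compound 2 to compound 3 (0.71 log units; beyond the scatter), both replacing a methoxycarbonyl-bearing chain with a hydroxyl-bearing one; an at least 1.2-fold lower number from compound 1 to compound 2 (0.09 log units; that floor lies within the scatter) shows that moving the ester within the chain stays within the scatter. For the measured compounds named here, compound 4 carries two hydroxyls where compound 3 carries one, and no measured compound tests a second hydroxyl. The expectation is therefore a step in this assay of about the size seen from compound 1 to compound 3, downward, so compound 4 is expected near the value of compound 3. Compound 4 is expected at 9000 nM, in the range 3000 nM to 30000 nM, which is the step of an at least 5.5-fold lower number from compound 1 to compound 4 (0.74 log units; beyond the scatter).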

Compound 4, half-maximal inhibitory concentration: 14100 nM
Estimate against measurement, compound 4: 1.6-fold (0.19 log units) below; measured number inside the range.
By their numbers in this assay, from the lowest: compounds 3 and 4 (each within the scatter of the next); then compound 2. At a limit, above all of these: compound 1.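

Replacing hydrogen with hydroxymethyl on a saturated chain carbon, two bonds along the chain from an amide-type nitrogen, gives a 1.8-fold higher number from compound 3 to compound 4 (0.26 log units; within the scatter), so in this assay the second hydroxyl is not resolved from the single-hydroxyl chain. The diol chain 3-hydroxy-1-(hydroxymethyl)propyl still stands apart from the ester chain 2-(methoxycarbonyl)ethyl, with a 2.9-fold lower number from compound 2 to compound 4 (0.46 log units; beyond the scatter). Against 1-(methoxycarbonyl)ethyl the same chain gives an at least 3.5-fold lower number from compound 1 to compound 4 (0.54 log units; beyond the scatter), which is only a floor, as compound 1 stands at a limit of the assay: the limit of > 50000 nM in this assay, at which 1 of the 4 values shown sits.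

Still open, from the compounds shown here alone, is how a carboxylic acid, an amine or a longer hydroxyl-bearing chain on this amide-type nitrogen would read. Also open, going by these compounds, is the effect of the opposite configuration at the defined stereocentre of 3-hydroxy-1-(hydroxymethyl)propyl.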